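A few compounds are considered here, and "the series" means these few. Any claim that something is new, unique, unknown or untested is made for them only; others in the source may bear on it.

For the measured compounds named here, in a functional assay on HepG2 cells (Homo sapiens) for cytotoxicity, read by MTT assay, with a stated time of 24 h (a higher number here means a weaker inhibitor, a lower number a stronger inhibitor), compound 2 `COc1cc(/C=C2\CN(S(=O)(=O)c3ccc(F)cc3)C/C(=C\c3cc(OC)c(OC)c(OC)c3)C2=O)cc(OC)c1OC` gives 4200 nM and sits within the usual scatter of compound 3 `N#Cc1ccc(/C=C2\CN(S(=O)(=O)c3ccc(F)cc3)C/C(=C\c3ccccc3F)C2=O)cc1` at 8180 nM on the numbers so far. Compound 1 `N#Cc1ccc(/C=C2\CN(S(=O)(=O)c3ccc(F)cc3)C/C(=C\c3ccc(C#N)cc3)C2=O)cc1` gives 11500 nM as a higher number, beyond the scatter from compound 2.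

The next compound to be measured is compound 4 `COc1cc(/C=C2\CN(S(=O)(=O)c3ccc(F)cc3)C/C(=C\c3cc(OC)c(OC)c(OC)c3)C2=O)cc(OC)c1` and it differs from compound 2 by one change: hydrogen in place of methoxy on an aromatic carbon in words, hydrogen in place of methoxy on an aromatic carbon, so that 3,4,5-trimethoxyphenyl becomes 3,5-dimethoxyphenyl.

Going by the values given here, no measured step removes a methoxy group. Among the compounds with values here, the only guide is a 1.4-fold lower number from compound 1 to compound 3 (0.15 log units; within the scatter) which replaces a different group and stays within the scatter. It bears on this change only loosely and gives no direction, so no step beyond the scatter is expected in this assay here. The estimated step is a 1.2-fold higher number from compound 2 to compound 4 (0.08 log units; within the scatter) and it is expected to stay within the scatter. For compound 4 the estimated value is 5000 nM with an expected range from 2200 nM to 11000 nM in this measurement.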

Compound 4, half-maximal inhibitory concentration: 3890 nM
For compound 4 the middle estimate is 1.3-fold (0.11 log units) above the measured one; the range from low to high includes it.
By their numbers in this assay, from the lowest: compounds 4, 2, 3 and 1 (each within the scatter of the next, the first and the last beyond it).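

In this assay, putting hydrogen in place of methoxy on an aromatic carbon, para to a large group, is a 1.1-fold lower number from compound 2 to compound 4 (0.03 log units; within the scatter), and this is the only step shown at this position. One of the two 3,4,5-trimethoxyphenyl groups can thus become 3,5-dimethoxyphenyl, losing a methoxy group of 2 heavy atoms, and the two compounds still cannot be told apart in this cell assay, so this methoxy group is not needed to keep the number where it is. Nothing measured here gives a reason for this result.

The compounds shown leave open whether an amine or a carboxylic acid on this same carbon would also stay within the scatter. They also leave open whether the two remaining methoxy groups on this ring could be replaced by hydrogen as well.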